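Swapping the Group on the Oxygen of Compound 2

The compounds below may be only part of what the source reports. "The series", "measured", "known", "first", "only" and "open" are said of these compounds alone.

Measured so far:
compound 1, `Cc1nn(-c2ncnc3nc[nH]c23)c2c1C(C(=O)NCc1ccc(F)cc1)CC(=O)N2`: 1220 nM
compound 2, `Cc1nn(-c2ncnc3nc[nH]c23)c2c1C(OCc1ccc(C(C)C)cc1)CC(=O)N2`: 1690 nM

Of the compounds shown here, two built on one shared core have been tested in a functional assay on HEK293 cells for agonist activity at G-protein coupled receptor 39 (Homo sapiens), read by scintillation proximity assay and inositol phosphate accumulation, with a stated time of 75 min; a lower number here means that less compound is needed, a higher number that more compound is needed for the effect. Compound 1 `Cc1nn(-c2ncnc3nc[nH]c23)c2c1C(C(=O)NCc1ccc(F)cc1)CC(=O)N2` gives 1220 nM, and compound 2 `Cc1nn(-c2ncnc3nc[nH]c23)c2c1C(OCc1ccc(C(C)C)cc1)CC(=O)N2` gives 1690 nM. Compound 2 has the higher of the two numbers, but its gap to compound 1 lies within the usual scatter, so the two cannot be told apart on these data.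

Compound 3 `Cc1nn(-c2ncnc3nc[nH]c23)c2c1C(OC(=O)c1ccc(F)cc1)CC(=O)N2` has not yet been measured. It comes from compound 2 through one change: (4-fluorophenyl)carbonyl in place of 4-isopropylbenzyl on an oxygen on a saturated carbon. Among the measured compounds shown here, no measured pair shows this change, so its effect is not known from the data. What the data do show is that compound 1 and compound 2, with quite different groups in this region, give numbers within the scatter of each other. On that basis the step of a 1.1-fold lower number from compound 2 to compound 3 (0.05 log units; within the scatter) in this assay is expected to be small, not beyond the scatter, with no clear direction. Compound 3 is therefore estimated at 1500 nM, with a range from 500 nM to 5000 nM.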

Compound 3, half-maximal effective concentration: 245 nM
Compound 3: middle estimate off by 6.1-fold (0.79 log units), on the high side; the measured number lies below the stated range.
By their numbers in this assay, from the lowest: compound 3; then compounds 1 and 2 (each within the scatter of the next).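

In this assay, the group on this oxygen turns out to matter: the change gives a 6.9-fold lower number from compound 2 to compound 3 (0.84 log units; beyond the scatter), a difference that the close numbers of compound 1 and compound 2 gave no hint of. The swap alters more than one thing at once, since (4-fluorophenyl)carbonyl brings a carbonyl with one hydrogen-bond acceptor and a fluorine, while 4-isopropylbenzyl has neither and carries an isopropyl group instead, so this single step cannot assign the lower number to any one of these parts. Nothing available here explains why the number drops.

From the compounds shown here alone, it remains open whether the carbonyl or the fluorine goes with the lower number, a question that a 4-fluorobenzyl group and a (4-isopropylphenyl)carbonyl group on this same oxygen would help to separate. Going by these compounds, it is also open how the number responds to other groups in this place, such as a smaller acetyl group or a (4-chlorophenyl)carbonyl group.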